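The source may report more compounds than this note shows. Statements on the series, on what has been measured and on what is new or still open speak of the compounds shown alone.

Measured so far:
compound 1 `O=C(CC1c2ccccc2N=C(N2CCOCC2)N1c1ccccc1)NCc1ccccc1` — 63.8%
compound 2 `O=C(CC1c2ccccc2N=C(c2ccccc2)N1c1ccccc1)OCc1ccccc1` — 14.2%
compound 3 `O=C(CC1c2ccccc2N=C(N2CCCCC2)N1c1ccccc1)OCc1ccccc1` — 15.6%

In a functional assay on cells (Oocyte) for inhibition of Voltage-dependent T-type calcium channel subunit alpha-1H (Homo sapiens), tested at 100 uM (on this read-out lower numbers stand for less inhibition and higher numbers for more inhibition at the one concentration tested (going by the name of the read-out)), compound 3 stands second highest of the three numbers. For the measured compounds named here, its nearest neighbour is compound 2, and the only measured step, a number 1.4 percentage points higher from compound 2 to compound 3 (within the scatter), is within the scatter, so the two cannot be ordered. Going by the values given here, compound 1 lies far above both; it carries the morpholin-4-yl group, but it also differs from compound 3 at the benzyl ester, which compound 1 replaces by a benzylamide, so no single-place step to compound 1 exists and its value shows only that a morpholin-4-yl compound of this series can reach high inhibition.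

Compound 4 `O=C(CC1c2ccccc2N=C(N2CCOCC2)N1c1ccccc1)OCc1ccccc1` is the next compound to be measured. It differs from compound 3 in one place: morpholin-4-yl in place of piperidin-1-yl on a carbon with a double bond to nitrogen. Among the compounds with values here, no measured step covers this exchange. Within the data shown here, the one step at the same position, a number 1.4 percentage points higher from compound 2 to compound 3 (within the scatter), was within the scatter, which argues for a small effect of changes at this carbon; the high value of compound 1 is the only hint toward an increase, and it is confounded by the ester-to-amide difference.

The expected outcome for compound 4 is therefore a step of a number 9.4 percentage points higher from compound 3 to compound 4 (within the scatter), modest and of uncertain direction, leaning upward. Compound 4 is estimated at 25% in this assay, with a range from 8% to 55%.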

Compound 4, a percentage reported as inhibition, at one concentration (the size of the read-out at that concentration, not a potency): 20.9%
Estimate against measurement, compound 4: 4.1 percentage points above; the range from low to high includes it.
By their numbers in this assay, from the lowest: compounds 2, 3 and 4 (each within the scatter of the next); then compound 1.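

In this assay, morpholin-4-yl in place of piperidin-1-yl gives a number 5.3 percentage points higher from compound 3 to compound 4 (within the scatter) and morpholin-4-yl in place of phenyl gives a number 6.7 percentage points higher from compound 2 to compound 4 (within the scatter) on the carbon with a double bond to nitrogen, so the three benzyl esters, compound 2, compound 3 and compound 4, cannot be ordered, and morpholin-4-yl on this carbon does not by itself carry a high value. The large change lies at the other place: benzyloxy in place of benzylamino on a carbonyl carbon gives a number 42.9 percentage points lower from compound 1 to compound 4 (beyond the scatter) with morpholin-4-yl held constant, so the high value of compound 1 goes with its benzylamino group. The data offer no explanation for this difference between the ester and the amide.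

Open is whether benzylamino on the carbonyl carbon gives a similar step with piperidin-1-yl or phenyl on the carbon with a double bond to nitrogen, since the compounds shown offer this exchange with morpholin-4-yl alone. Also open, as far as these compounds go, is how a carboxylic acid or a methylamino group on that carbonyl carbon would read in this assay, where only benzyloxy and benzylamino can be compared so far.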